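The source may report more compounds than this note shows. Statements on the series, on what has been measured and on what is new or still open speak of the compounds shown alone.

Compound 3 `CN1O[C@H](n2ccnn2)C[C@@H]1CO` stands second highest of the three numbers in a functional assay on 8305C cells (Homo sapiens) for cytotoxicity, read by MTT assay, with a stated time of 24 h (on this read-out lower numbers stand for stronger inhibition and higher numbers for weaker inhibition), where compound 3 gives 8130 nM; compound 2 `CN1O[C@H](n2cc(-c3ccccc3)nn2)C[C@@H]1CO` gives 8760 nM, and compound 1 `CCCc1cn([C@H]2C[C@H](CO)N(C)O2)nn1` gives 5820 nM. Compound 4 `CCCc1cn([C@@H]2C[C@H](CO)N(C)O2)nn1` carries propyl in place of hydrogen on an aromatic carbon. Among the measured compounds shown here, the one step that bears on a change at this ring carbon is a 1.1-fold lower number from compound 2 to compound 3 (0.03 log units; within the scatter), which shows the read-out barely moving when a group at that position is removed. Compound 1, which also carries a propyl group on this ring, sits close to compound 3 in this assay. A step no larger than the scatter is therefore expected, a 1.3-fold lower number from compound 3 to compound 4 (0.10 log units; within the scatter), and compound 4 is estimated at 6500 nM, with a range from 3000 nM to 14000 nM.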

Compound 4, half-maximal inhibitory concentration: 6870 nM
The estimate for compound 4 lay 1.1-fold (0.02 log units) below the measured number; the measured number falls inside the stated range.
By their numbers in this assay, from the lowest: compounds 1, 4, 3 and 2 (each within the scatter of the next).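

In this assay, propyl in place of hydrogen on the aromatic carbon gives a 1.2-fold lower number from compound 3 to compound 4 (0.07 log units; within the scatter), and propyl in place of phenyl gives a 1.3-fold lower number from compound 2 to compound 4 (0.11 log units; within the scatter), so neither change at this position moves the read-out beyond the scatter. Changing the drawn stereocentre at the saturated ring carbon also stays within the scatter, with a 1.2-fold higher number from compound 1 to compound 4 (0.07 log units; within the scatter), and this pair isolates that one change: the fact that compounds 1 and 4 differ only in the configuration as drawn. Left open is whether an amine, a carboxylic acid or a longer chain on the aromatic carbon would shift the number beyond the scatter.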